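This account rests on a few compounds, and the source may have more. Where it says the series, first, only, none or still open, it means among the compounds named here.

For the measured compounds named here, in a functional assay on DU-145 cells (Homo sapiens) for cytotoxicity, read by MTT assay, with a stated time of 24 h (a higher number here means a weaker inhibitor, a lower number a stronger inhibitor), compound 1 `CCCCCC(=O)Nc1nnc(S[C@@H]2O[C@H](COC(C)=O)[C@H](OC(C)=O)[C@H](OC(C)=O)[C@H]2OC(C)=O)s1` is reported as "not active" (no number reported), which leaves compound 2 `CCCCCCCC/C=C\CCCCCCCCCCCC(=O)Nc1nnc(S[C@@H]2O[C@H](COC(C)=O)[C@H](OC(C)=O)[C@H](OC(C)=O)[C@H]2OC(C)=O)s1`, at 28400 nM, as the only number available. Compound 3 `CCCCCCCCCCCCCCCC(=O)Nc1nnc(S[C@@H]2O[C@H](COC(C)=O)[C@H](OC(C)=O)[C@H](OC(C)=O)[C@H]2OC(C)=O)s1` keeps the shared core but carries a shorter chain end: butyl in place of dec-1-en-1-yl on a saturated chain carbon, ten or more bonds along the chain from a carbonyl carbon, with butyl in place of dec-1-en-1-yl on a saturated chain carbon, ten or more bonds along the chain from a carbonyl carbon. Going by the values given here, no measured step is available as a guide, so no shift beyond the scatter is expected in this assay. The estimated step is a 1.1-fold higher number from compound 2 to compound 3 (0.02 log units; within the scatter). Compound 3 is expected at 30000 nM, within a range of 12000 nM to 75000 nM.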

Compound 3, half-maximal inhibitory concentration: 30100 nM
The estimate for compound 3 lay 1.0-fold (0.00 log units) below the measured number; the range from low to high includes it.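

In this assay, putting butyl in place of dec-1-en-1-yl on a saturated chain carbon, ten or more bonds along the chain from a carbonyl carbon, gives a 1.1-fold higher number from compound 2 to compound 3 (0.03 log units; within the scatter). At this far part of the chain, then, losing the double bond and six carbons together leaves the number within the usual scatter. No measurement here offers an explanation for this result.

On these data alone, the two differences travel together, so the effect of the double bond alone stays open. Also open, as far as these compounds go, is how a chain ending in an amine or a carboxylic acid would behave.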